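The compounds below may be only part of what the source reports. "The series", "measured", "known", "first", "only" and "open" are said of these compounds alone.

Compound 1 `COc1ccccc1S(=O)(=O)/C=C/c1ncccc1F` and compound 3 `COc1cccc(S(=O)(=O)/C=C/c2ncccc2F)c1` are built from the same atoms joined differently; how their two cores differ is not broken down here. In an assay on U2OS cells for activation of nuclear factor erythroid 2-related factor 2 (Homo sapiens), read by chemiluminescence, with a stated time of 6 h (on this read-out higher numbers stand for an effect only at larger amounts of compound and lower numbers for an effect already at smaller amounts), compound 1 gives 877 nM, and compound 3 gives 444 nM, a gap that lies within the usual scatter, so the two are treated as indistinguishable. Compound 2 `COc1ccccc1S(=O)(=O)/C=C/c1ncccc1Cl` carries the change (chloro in place of fluoro on an aromatic carbon), and in this assay compound 2 gives 142 nM; the step of a 6.2-fold lower number from compound 1 to compound 2 (0.79 log units; beyond the scatter) is a modest one but beyond the scatter. Compound 4 `COc1cccc(S(=O)(=O)/C=C/c2ncccc2Cl)c1` has not yet been measured; it differs from compound 3 by chloro in place of fluoro on an aromatic carbon, the same change at the same place, made twice in all among these compounds. Because the step of a 6.2-fold lower number from compound 1 to compound 2 (0.79 log units; beyond the scatter) was clearly resolved, compound 4 is expected to move in the same direction from compound 3, and the estimated step is a 4.9-fold lower number from compound 3 to compound 4 (0.69 log units; beyond the scatter), allowed to come out somewhat smaller since a single prior pair is a thin basis. The value for compound 4 in this assay is accordingly estimated at 90 nM, with a likely range from 35 nM to 250 nM.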

Compound 4, half-maximal effective concentration: 98 nM
The estimate for compound 4 lay 1.1-fold (0.04 log units) below the measured number, and the stated range covers the measured number.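

In this assay chloro in place of fluoro on an aromatic carbon gives a 4.5-fold lower number from compound 3 to compound 4 (0.66 log units; beyond the scatter) and so repeats the direction of the earlier step. Set beside that earlier step, the change carries from one core to the other with no difference in size that can be told apart: the same change on two cores in this assay, a 6.2-fold lower number (0.79 log units; beyond the scatter) from compound 1 to compound 2 and a 4.5-fold lower number (0.66 log units; beyond the scatter) from compound 3 to compound 4, 1.4-fold (0.13 log units) apart, within the scatter of two such steps. Within the data shown here, this rests on only two pairs in a single assay, so it shows that the step holds on the core of compound 1 and the core of compound 3, but not that it would hold on any further core, nor why the chloro compounds give the lower numbers.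

The compounds shown leave open whether another group at the same place on the ring, such as bromo, methyl or a nitrile, would go the way of chloro. They also leave open whether an amine or a carboxylic acid in place of the methoxy group would keep the effect.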